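Swapping the aryl group on the shared core

A few compounds are considered here, and "the series" means these few. Any claim that something is new, unique, unknown or untested is made for them only; others in the source may bear on it.

Of the compounds shown here, three built on one shared core have been tested in a functional assay on ECa-109 cells for inhibition, with ECa-109 cell line (Homo sapiens) as the target, read by sulforhodamine B assay; on this read-out lower numbers stand for stronger inhibition and higher numbers for weaker inhibition. Compound 1 `O=C1C(Nc2ccccc2F)=CC(=O)c2c1nc1n2[C@H]2OC[C@@H](O)[C@H]2OC1` gives 2660 nM, the lowest of the three numbers. Compound 2 `CCc1ccc(NC2=CC(=O)c3nc4n(c3C2=O)[C@H]2OC[C@@H](O)[C@H]2OC4)cc1` gives 3080 nM, within the usual scatter of compound 1. For the measured compounds named here, compound 3 `O=C1C=C(Nc2cccc(F)c2)C(=O)c2c1nc1n2[C@H]2OC[C@@H](O)[C@H]2OC1` gives 7030 nM, and the single change of a 2.3-fold higher number from compound 2 to compound 3 (0.36 log units; beyond the scatter) is a modest weakening.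

Compound 4 `COc1ccc(NC2=CC(=O)c3c(nc4n3[C@H]3OC[C@@H](O)[C@H]3OC4)C2=O)cc1` differs from compound 1 in one place: 4-methoxyphenyl in place of 2-fluorophenyl on an amine nitrogen. Going by the values given here, no measured step shows this exact exchange. Among the compounds with values here, the nearest guide is that compound 2, which also carries a group at the 4-position of the phenyl ring, sits within scatter of compound 1, while the only step beyond scatter, from compound 2 to compound 3, involved a 3-fluorophenyl group that compound 4 does not carry. The expectation for compound 4 in this assay is therefore a step of a 1.1-fold higher number from compound 1 to compound 4 (0.05 log units; within the scatter), that is, no change beyond the scatter. Compound 4 is estimated at 3000 nM, with a range from 1500 nM to 6000 nM.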

Compound 4, half-maximal inhibitory concentration: 3410 nM
Estimate against measurement, compound 4: 1.1-fold (0.06 log units) below, and the stated range covers the measured number.
By their numbers in this assay, from the lowest: compounds 1, 2 and 4 (each within the scatter of the next); then compound 3.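

In this assay, the exchange of 2-fluorophenyl for 4-methoxyphenyl on the amine nitrogen gives a 1.3-fold higher number from compound 1 to compound 4 (0.11 log units; within the scatter), so this position takes the change without a readable shift in the number. Fluorine on the aryl ring is therefore not required to stay within the scatter of compound 1, and the larger group, which brings a hydrogen-bond acceptor, does not move the result beyond it either. Nothing available here explains why this exchange leaves the number within the scatter.

Still open, going by these compounds, is how a carboxylic acid or a dimethylamino group on the phenyl ring would read in this assay. On these data alone, it is also open whether the amine nitrogen needs an aryl ring at all, or whether a plain butyl chain could take its place.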